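Shortening the bromoalkyl side chain: compound 3 to compound 4

The source may report more compounds than this note shows. Statements on the series, on what has been measured and on what is new or still open speak of the compounds shown alone.

Compound 3 `BrCCCOc1c(Br)cc(Br)cc1Oc1ccc(Br)cc1Br` gives 30.3 ug/mL in a functional assay on U-937 cells (Homo sapiens) for cytotoxicity, read by MTT assay, with a stated time of 24 h; on this read-out higher numbers stand for weaker inhibition and lower numbers for stronger inhibition. Compound 1 `C=CCOc1c(Br)cc(Br)cc1Oc1ccc(Br)cc1Br` gives 29 ug/mL and compound 2 `Brc1ccc(Oc2cc(Br)cc(Br)c2OCCCCCN2CCN(C/C=C/c3ccccc3)CC2)c(Br)c1` gives 32.7 ug/mL; all three numbers lie within the scatter of one another, so compound 3 cannot be set apart from either. Compound 4 `BrCCOc1c(Br)cc(Br)cc1Oc1ccc(Br)cc1Br` differs from compound 3 by bromo in place of bromomethyl on a saturated chain carbon, two bonds along the chain from an oxygen on an aromatic ring. For the measured compounds named here, the only step at the same place, a 1.0-fold higher number from compound 1 to compound 3 (0.02 log units; within the scatter), changed nothing of note, and compound 2, with a quite different side chain, also gives 32.7 ug/mL, a number in the same band. Among these compounds the side chain thus appears not to move the read-out, and the expected step of a 1.0-fold lower number from compound 3 to compound 4 (0.00 log units; within the scatter) is none beyond the scatter. Compound 4 is accordingly estimated at 30 ug/mL, with a range of 16 ug/mL to 58 ug/mL.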

Compound 4, half-maximal inhibitory concentration: 32.5 ug/mL
Compound 4: middle estimate off by 1.1-fold (0.03 log units), on the low side, within the range that was stated.
By their numbers in this assay, from the lowest: compounds 1, 3, 4 and 2 (each within the scatter of the next).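

Cutting 3-bromopropoxy to 2-bromoethoxy gives a 1.1-fold higher number from compound 3 to compound 4 (0.03 log units; within the scatter) in this assay and so adds a second change at this chain that stays inside the scatter, this time a shortening of the bromoalkyl chain itself. Bromomethyl in place of vinyl on the saturated chain carbon bound to the oxygen gives a 1.1-fold higher number from compound 1 to compound 4 (0.05 log units; within the scatter) and does not separate these two ethers either. No evidence on why the chain changes leave the read-out unmoved is at hand.

As far as these compounds go, whether a carboxylic acid or a hydroxyl at the chain end would leave this band remains open.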